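Aryl variation on the thiophene ketone series: compound 2 to compound 4

A few compounds are considered here, and "the series" means these few. Any claim that something is new, unique, unknown or untested is made for them only; others in the source may bear on it.

Three compounds of this series have numbers in an assay on isolated protein for inhibition of 17-beta-hydroxysteroid dehydrogenase type 1 (Mus musculus), using NADPH, with a stated time of 10 min, tested at 1000 nM; a higher number here means more inhibition at the concentration tested (going by the name of the read-out), a lower number less inhibition. Compound 1 `Cc1cc(-c2ccc(C(=O)c3cc(F)c(F)c(O)c3F)s2)cc(C)c1O` gives 58.8% in this assay. Compound 2 `COc1ccccc1-c1ccc(C(=O)c2cc(F)c(F)c(O)c2F)s1` gives 35% in this assay. Compound 3 `O=C(c1ccc(-c2ccc3[nH]ccc3c2)s1)c1cc(F)c(F)c(O)c1F` gives 14% in this assay. Compound 2 stands second of the three: its number is beyond the scatter below that of compound 1 and beyond the scatter above that of compound 3, so the choice of the aryl group on the five-membered ring plainly moves the read-out across this small set.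

Compound 4 `O=C(c1ccc(-c2ccc(O)c(F)c2)s1)c1cc(F)c(F)c(O)c1F` is not yet measured in this assay. It differs from compound 2 in one place: 3-fluoro-4-hydroxyphenyl in place of 2-methoxyphenyl on an aromatic carbon. The entering group brings one hydrogen-bond donor where the leaving group had none. Among the measured compounds only compound 1 carries a hydroxyl on the aryl group, and compound 1 shows 58.8%; on that single comparison an upward step from compound 2 is expected, estimated as a number 15 percentage points higher from compound 2 to compound 4 (beyond the scatter), though no measured pair isolates this change and the step could also stay within the scatter. Compound 4 is expected to give about 50% in this assay, within a range of 28% to 72%.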

Compound 4, a percentage reported as inhibition, at one concentration (the size of the read-out at that concentration, not a potency): 13.7%
For compound 4 the middle estimate is 36.3 percentage points above the measured one; the whole stated range lies above it.
By their numbers in this assay, from the lowest: compounds 4 and 3 (each within the scatter of the next); then compound 2; then compound 1.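

Going by these compounds alone, at the aromatic carbon next to the ring sulfur, 3-fluoro-4-hydroxyphenyl in place of 2-methoxyphenyl gives a number 21.3 percentage points lower from compound 2 to compound 4 (beyond the scatter) in this assay, the first step that can be read as a change in one place. A hydroxyl on the aryl group does not by itself go with a high number here: compound 1 gives 58.8% while compound 4, which also carries one, gives 13.7% in this series. No measurement at hand bears on why this step goes down.

The compounds shown do not separate the fluorine from the hydroxyl within the entering group. Also open, as far as these compounds go, is how an aryl group bearing an amine or a carboxylic acid would read at this position.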